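This account rests on a few compounds, and the source may have more. Where it says the series, first, only, none or still open, it means among the compounds named here.

Measured so far in a functional assay on L1210 cells (Mus musculus) for antiproliferative activity; a higher number here means a weaker inhibitor, a lower number a stronger inhibitor:
- compound 1 `COc1cc(C(=O)c2sc(-c3ccccc3)cc2N)cc(OC)c1OC`: 11 nM
- compound 2 `COc1cc(C(=O)c2sc(-c3ccncc3)cc2N)cc(OC)c1OC`: 1810 nM
- compound 3 `COc1cc(C(=O)c2sc(-c3ccc(F)cc3)cc2N)cc(OC)c1OC`: 20 nM

Compound 1 shares the low end of this small set with compound 3: the step of a 1.8-fold higher number from compound 1 to compound 3 (0.26 log units; within the scatter) stays within the scatter. Compound 2 stands well apart, with a 160-fold higher number from compound 1 to compound 2 (2.22 log units; beyond the scatter) and a 91-fold lower number from compound 2 to compound 3 (1.96 log units; beyond the scatter), both large.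

Compound 4 `COc1ccc(-c2cc(N)c(C(=O)c3cc(OC)c(OC)c(OC)c3)s2)cc1` has not yet been measured. It differs from compound 1 as follows: methoxy in place of hydrogen on an aromatic carbon. In words, this is methoxy in place of hydrogen on an aromatic carbon, with phenyl becoming 4-methoxyphenyl.

Among the measured compounds shown here, the nearest precedent is compound 3, where a small group also replaces hydrogen on the phenyl, giving a 1.8-fold higher number from compound 1 to compound 3 (0.26 log units; within the scatter). The large step to compound 2 replaces the phenyl itself, so it bears less directly on this change. For the measured compounds named here, no methoxy example has been measured, and a single precedent gives only limited support.

In this assay, a small shift toward a higher number is therefore expected, with no step beyond the scatter. The estimated step is a 1.8-fold higher number from compound 1 to compound 4 (0.26 log units; within the scatter). For compound 4 the estimated value is 20 nM, with an expected range from 7 nM to 70 nM.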

Compound 4, half-maximal inhibitory concentration: 45 nM
Compound 4: the middle estimate sits 2.3-fold (0.35 log units) below what was measured; low and high end bracket the measured number.
By their numbers in this assay, from the lowest: compounds 1 and 3 (each within the scatter of the next); then compound 4; then compound 2.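

Working notes on the series: in this assay, the six-membered aromatic ring does not accept every replacement of hydrogen para to a large group without a shift beyond the scatter. Methoxy in place of hydrogen gives a modest change (a 4.1-fold higher number from compound 1 to compound 4 (0.61 log units; beyond the scatter)), and methoxy can also be told apart from fluoro (a 2.3-fold higher number from compound 3 to compound 4 (0.35 log units; beyond the scatter)), which the fluoro compound alone could not show, since its own step from the unsubstituted phenyl stayed within the scatter. Even so, the methoxy change remains small beside the change of the ring itself (a 40-fold lower number from compound 2 to compound 4 (1.60 log units; beyond the scatter)), so among the compounds shown, neither fluoro nor methoxy at this place comes close to the large loss seen with pyridin-4-yl. No measured data accompany these numbers that would account for the difference between the groups.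

From the compounds shown here alone, how an amine, a carboxylic acid or a longer chain such as ethoxy would behave at this place remains open, and so does whether the step grows from methoxy to longer alkoxy chains. Also open, going by these compounds, is whether methoxy elsewhere on the phenyl gives a step of the same size as it does here.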